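Amide nitrogen substituent: from tert-butyl to isobutyl

A few compounds are considered here, and "the series" means these few. Any claim that something is new, unique, unknown or untested is made for them only; others in the source may bear on it.

Within the data shown here, in a functional assay on the whole organism for inhibition, with Brassica rapa subsp. chinensis as the target, with a stated time of 3 days, tested at 100 ppm (a higher number here means more inhibition of growth at the concentration tested, a lower number less inhibition of growth), compound 2 `CC(C)(C)NC(=O)/C=C/c1ccccc1` gives 34% and stands lowest of the two numbers so far. Compound 1 `CCCCCCNC(=O)/C=C/c1ccccc1` gives 55% and lies above it by a gap beyond the usual scatter.

The next compound to read is compound 3 `CC(C)CNC(=O)/C=C/c1ccccc1` with the same atoms as compound 2 joined differently. The change is isobutyl in place of tert-butyl on an amide-type nitrogen and amounts to isobutyl in place of tert-butyl on an amide-type nitrogen.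

Among the measured compounds shown here, no measured pair differs in one place only, so no direct step is available as a guide for this change. For the measured compounds named here, the expectation rests on two values alone, with compound 2 at 34% as the starting point and compound 1 at 55% as the one higher reference in this assay so far. The step of a number 10 percentage points higher from compound 2 to compound 3 (within the scatter) is expected to be upward and modest, near the edge of the usual scatter. Compound 3 is estimated at 44% with 30% to 60% as the expected range.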

Compound 3, percent growth inhibition at one concentration: 34%
Beside the measured number, compound 3's estimate is 10 percentage points above it; measured number inside the range.
By their numbers in this assay, from the lowest: compounds 2 and 3 (each within the scatter of the next); then compound 1.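

In this assay, isobutyl in place of tert-butyl on an amide-type nitrogen gives no change at the digits printed from compound 2 to compound 3 (within the scatter), so rearranging the same carbon atoms at this position does not separate the two compounds in this read-out. Isopropyl in place of pentyl on a saturated chain carbon bound to an amide-type nitrogen gives a number 21 percentage points lower from compound 1 to compound 3 (beyond the scatter), which is the first one-place comparison in the series to show that growth inhibition responds to a change in this substituent. Nothing at hand bears on the reason for either step.

With only these three amides, the position has a single step beyond the scatter, and that step cannot show whether the decisive feature is the length of the chain or its branching, as the comparison with compound 1 alters both at once. Going by these compounds, an unbranched butyl group on the same nitrogen would sit between these cases, while a longer chain such as decyl, or a ring such as cyclohexyl, remains open as a way to find how far the response at this position extends.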